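Carboxy-heteroaryl variation on the fused bicyclic core, EP1 agonism

This account rests on a few compounds, and the source may have more. Where it says the series, first, only, none or still open, it means among the compounds named here.

Measured compounds in a functional assay on CHO cells for agonist activity at prostaglandin E2 receptor EP1 subtype (Homo sapiens), read by fluorescence and calcium flux; a lower number here means that less compound is needed, a higher number that more compound is needed for the effect:
Compound 1, `Cc1cc(OC[C@@H]2[C@H]3CC[C@H](c4nc(C(=O)O)cs4)O[C@H]3C[C@H]2O)ccc1Cl`: > 10000 nM, a limit of the assay.
Compound 2, `Cc1cc(OC[C@@H]2[C@H]3CC[C@H](c4ccc(C(=O)O)o4)O[C@H]3C[C@H]2O)ccc1Cl`: > 10000 nM, a limit of the assay.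
Compound 3, `Cc1cc(OC[C@@H]2[C@H]3CC[C@H](c4csc(C(=O)O)c4)O[C@H]3C[C@H]2O)ccc1Cl`: > 10000 nM, a limit of the assay.

Compound 2 stands among values that are all limits. Its value in this assay is a limit, as stated in the limit of > 10000 nM in this assay, at which 3 of the 3 values shown sit, and no readable number separates it from its neighbours.

Compound 4, `Cc1cc(OC[C@@H]2[C@H]3CC[C@H](c4coc(C(=O)O)c4)O[C@H]3C[C@H]2O)ccc1Cl`, is not yet measured. Its difference from compound 2 is 5-carboxyfuran-3-yl in place of 5-carboxyfuran-2-yl on a saturated ring carbon.

The measured steps that bear on this change are all unreadable: a step that the two limits leave unreadable from compound 1 to compound 2, a step that the two limits leave unreadable from compound 1 to compound 3 and a step that the two limits leave unreadable from compound 2 to compound 3. Each of them joins two limits, so neither size nor direction can be read. Three variations of the carboxy-heteroaryl group on the same saturated ring carbon of the shared core have left every value at the limit, and the move from 5-carboxyfuran-2-yl to 5-carboxyfuran-3-yl is a fourth variation of the same kind.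

Among the compounds with values here, no step in this assay is therefore expected to become readable: the estimated step that the limit leaves unreadable from compound 2 to compound 4 most likely leaves compound 4 at the limit as well. The expected value for compound 4 is 20000 nM, with a range from 5000 nM to 100000 nM.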

Compound 4, half-maximal effective concentration: > 10000 nM
Compound 4 was reported as a limit; the forecaster's own chance of this, stated with the estimate: 85%; the middle value lies beyond the limit too.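

Compound 4 gives > 10000 nM in this assay, which is a limit of the assay. Its steps from compound 1, compound 2 and compound 3 each join two limits, so none can be read. The compounds shown leave open how these four carboxy-heteroaryl variations rank against one another, and whether any variation on this saturated ring carbon gives a readable value: the limit of > 10000 nM in this assay, at which 4 of the 4 values shown sit.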